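A few compounds are considered here, and "the series" means these few. Any claim that something is new, unique, unknown or untested is made for them only; others in the source may bear on it.

Compound 1, `c1coc(-c2ccccc2OCC2=NCCN2)c1`, in a functional assay for activation of Alpha-1B adrenergic receptor (Homo sapiens), read by calcium flux; a higher number here means that more compound is needed for the effect, a lower number that less compound is needed: 10 nM
Compound 2, `c1csc(-c2ccccc2OCC2=NCCN2)c1`, in this assay: 3.98 nM
Compound 3, `Cc1ccc(-c2ccccc2OCC2=NCCN2)s1`, in this assay: only a limit, < 100000 nM

Of the three measured compounds, compound 3 stands apart, since its result in this assay is a limit and not a number, (the limit of < 100000 nM in this assay, at which 1 of the 3 values shown sits). Among the two full numbers, the step of a 2.5-fold lower number from compound 1 to compound 2 (0.40 log units; beyond the scatter) accompanies thiophen-2-yl in place of furan-2-yl. The steps from compound 1 and from compound 2 to compound 3, a step that the limit leaves unreadable from compound 1 to compound 3 and a step that the limit leaves unreadable from compound 2 to compound 3, cannot be read in size, so the effect of the methyl group on the thiophene is not known.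

Compound 4, `Cc1csc(-c2ccccc2OCC2=NCCN2)n1`, carries the change (4-methyl-1,3-thiazol-2-yl in place of 5-methylthiophen-2-yl on an aromatic carbon). Going by the values given here, no measured step bears directly on this exchange of a thiophene for a thiazole, and the one step to compound 3 that could anchor it is unreadable. The expectation for compound 4 therefore rests on little: compound 1 and compound 2 show that the unmethylated analogues sit in the low range, while compound 3 gives only a limit. The estimate for compound 4 is 1000 nM, within 10 nM to 100000 nM, which as a step means a step that the limit leaves unreadable from compound 3 to compound 4 and is expected only as a broad guess.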

Compound 4, half-maximal effective concentration: < 100000 nM
Compound 4 was reported as a limit; the forecaster's own chance of this, stated with the estimate: 30%; the middle value is on the limit's open side.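

In this assay, compound 4 is reported only as a limit, as is compound 3, so its steps from compound 1, compound 2 and compound 3 cannot be read in size: the limit of < 100000 nM in this assay, at which 2 of the 4 values shown sit.

The compounds shown leave open whether 4-methyl-1,3-thiazol-2-yl or 5-methylthiophen-2-yl gives the lower number, and how far either lies from thiophen-2-yl.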